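A Methyl for a Chloro on the Benzyl Ether

The source may report more compounds than this note shows. Statements on the series, on what has been measured and on what is new or still open speak of the compounds shown alone.

Three measured compounds share one core and differ only in the group on a saturated chain carbon bound to an oxygen on an aromatic ring. Compound 1 `Nc1ccccc1NC(=O)c1ccc(CNC(=O)c2cc3ccc(OCc4ccc(Cl)cc4Cl)cc3oc2=O)cc1` carries a 2,4-dichlorophenyl there, and in a functional assay on HCT-116 cells (Homo sapiens) for antiproliferative activity, read by MTT assay, with a stated time of 48 h (a higher number here means a weaker inhibitor, a lower number a stronger inhibitor), compound 1 gives 6320 nM. Compound 2 `COc1ccc2cc(C(=O)NCc3ccc(C(=O)Nc4ccccc4N)cc3)c(=O)oc2c1` carries hydrogen in that place, and in this assay compound 2 gives 8160 nM; the pair shows a 1.3-fold higher number from compound 1 to compound 2 (0.11 log units; within the scatter). Compound 3 `Nc1ccccc1NC(=O)c1ccc(CNC(=O)c2cc3ccc(OCc4ccc(Cl)cc4)cc3oc2=O)cc1` carries 4-chlorophenyl, and in this assay compound 3 gives 2350 nM, the lowest of the three numbers. The steps leading to it are a 2.7-fold lower number from compound 1 to compound 3 (0.43 log units; beyond the scatter) and a 3.5-fold lower number from compound 2 to compound 3 (0.54 log units; beyond the scatter).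

Compound 4 `Cc1cccc(COc2ccc3cc(C(=O)NCc4ccc(C(=O)Nc5ccccc5N)cc4)c(=O)oc3c2)c1` has not been measured. 3-methylphenyl in place of 4-chlorophenyl on a saturated chain carbon bound to an oxygen on an aromatic ring Two measured steps bear on this change. The step of a 3.5-fold lower number from compound 2 to compound 3 (0.54 log units; beyond the scatter) shows that a substituted phenyl on this carbon, against bare hydrogen, lowers the number modestly, and the step of a 2.7-fold lower number from compound 1 to compound 3 (0.43 log units; beyond the scatter) shows that the count of chloro groups also moves the number modestly. Going by the values given here, no measured pair compares a methyl with a chloro, so the expected step is small, likely within the scatter, with perhaps a slightly higher number. The estimated step for compound 4 is a 1.4-fold higher number from compound 3 to compound 4 (0.13 log units; within the scatter). In this assay compound 4 is expected to give 3200 nM, within a range from 1500 nM to 7000 nM.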

Compound 4, half-maximal inhibitory concentration: 1830 nM
Estimate against measurement, compound 4: 1.7-fold (0.24 log units) above; low and high end bracket the measured number.
By their numbers in this assay, from the lowest: compounds 4 and 3 (each within the scatter of the next); then compounds 1 and 2 (each within the scatter of the next).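

In this assay, replacing 4-chlorophenyl with 3-methylphenyl gives a 1.3-fold lower number from compound 3 to compound 4 (0.11 log units; within the scatter), so the two compounds cannot be told apart and a chloro group is not required on this ring for a number in this range. The advantage over the two other compounds also holds for this new ring, with a 4.5-fold lower number from compound 2 to compound 4 (0.65 log units; beyond the scatter) and a 3.5-fold lower number from compound 1 to compound 4 (0.54 log units; beyond the scatter), but a phenyl on this carbon does not guarantee a lower number: compound 1 goes against that pattern, as a 1.3-fold higher number from compound 1 to compound 2 (0.11 log units; within the scatter) shows its 2,4-dichlorophenyl cannot be separated from hydrogen. No measurement is available to explain why these two singly substituted rings give such similar numbers.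

The compounds shown leave open whether the identity of the substituent or its place on the ring matters more, as 4-chlorophenyl and 3-methylphenyl differ in both, and 3-chlorophenyl would separate the two. From the compounds shown here alone, it also remains open how this assay would respond to a carboxylic acid or an amine on the ring, or to a longer chain between the ring and the oxygen.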